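A few compounds are considered here, and "the series" means these few. Any claim that something is new, unique, unknown or untested is made for them only; others in the source may bear on it.

Measured so far:
Compound 1, `Cc1ccc(-n2cc(COc3cccc(NC(=O)Nc4ccc(Cl)c(C(F)(F)F)c4)c3)nn2)cc1`: 5430 nM
Compound 2, `O=C(Nc1cccc(OCc2cn(-c3cccc(I)c3)nn2)c1)Nc1ccc(Cl)c(C(F)(F)F)c1`: 4780 nM

Among the compounds with values here, in a functional assay on HepG2 cells (Homo sapiens) for inhibition, read by MTT assay, with a stated time of 72 h (a lower number here means a stronger inhibitor, a higher number a weaker inhibitor), compound 2 gives 4780 nM, the lower of the two numbers; compound 1 gives 5430 nM, and the only measured step, a 1.1-fold lower number from compound 1 to compound 2 (0.06 log units; within the scatter), is within the scatter. Compound 3, `O=C(Nc1cccc(OCc2cn(-c3ccccc3C(F)(F)F)nn2)c1)Nc1ccc(Cl)c(C(F)(F)F)c1`, differs from compound 2 by 2-(trifluoromethyl)phenyl in place of 3-iodophenyl on an aromatic nitrogen. Within the data shown here, the one measured step bears on it, since it also swapped the aryl on that aromatic nitrogen, and it changed nothing beyond the scatter. Compound 3 is therefore expected to give 5000 nM in this assay, within 2500 nM to 10000 nM, an expected step of a 1.0-fold higher number from compound 2 to compound 3 (0.02 log units; within the scatter).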

Compound 3, half-maximal inhibitory concentration: 2320 nM
The estimate for compound 3 lay 2.2-fold (0.33 log units) above the measured number; the measured number lies below the stated range.
By their numbers in this assay, from the lowest: compound 3; then compounds 2 and 1 (each within the scatter of the next).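

In this assay, the group on the aromatic nitrogen now makes a difference beyond the scatter: 2-(trifluoromethyl)phenyl gives a 2.1-fold lower number from compound 2 to compound 3 (0.31 log units; beyond the scatter) and a 2.3-fold lower number from compound 1 to compound 3 (0.37 log units; beyond the scatter) while both steps stay modest, and 3-iodophenyl and 4-methylphenyl had not separated. No evidence is at hand that accounts for these steps. As far as these compounds go, it remains open whether the trifluoromethyl group itself or its place on the phenyl ring carries the change, and what a phenyl ring bearing an amine or a carboxylic acid would give at this position.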